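From pyridin-2-yl to pyrazin-2-yl on a shared core

The source may report more compounds than this note shows. Statements on the series, on what has been measured and on what is new or still open speak of the compounds shown alone.

In a physicochemical assay for solubility, in phosphate buffer, with a stated time of 2 h, at pH 7.4 (a higher number here means a more soluble compound, a lower number a less soluble compound), compound 1 (`Clc1ccc(Nc2nc(-c3ccccn3)cs2)nc1`) gives < 10000 nM, which is a limit. Compound 2 (`COc1ccc(-c2csc(Nc3ccc(Cl)cn3)n2)nc1`) gives < 10000 nM, also a limit. Compound 3 (`COc1cccc(-c2csc(Nc3ccc(Cl)cn3)n2)n1`) gives < 10000 nM, again a limit. The measurements therefore offer only (the limit of < 10000 nM in this assay, at which 3 of the 3 values shown sit).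

Compound 4 (`Clc1ccc(Nc2nc(-c3cnccn3)cs2)nc1`) differs from compound 1 by one exchange: pyrazin-2-yl in place of pyridin-2-yl on an aromatic carbon. Two measured steps offer the nearest comparison, a step that the two limits leave unreadable from compound 1 to compound 2 and a step that the two limits leave unreadable from compound 1 to compound 3. Each places methoxy in place of hydrogen on an aromatic carbon, and neither has a readable size. No step beyond the scatter, in either direction, is therefore expected in this assay. The expected change is a step that the limit leaves unreadable from compound 1 to compound 4. Compound 4 is estimated at 6000 nM, with an expected range of 1500 nM to 15000 nM.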

Compound 4, solubility: < 10000 nM
Compound 4: a limit, no number; the forecaster's own chance of this, stated with the estimate: 75%; the middle value is on the limit's open side.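

In this assay compound 4 gives < 10000 nM, a limit, so the step from compound 1 to compound 4 cannot be read. The compounds shown leave open whether pyrazin-2-yl in place of pyridin-2-yl changes solubility at all.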